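Trifluoromethyl for Trifluoromethoxy on a Shared Aromatic Carbon

The compounds below may be only part of what the source reports. "The series", "measured", "known", "first", "only" and "open" are said of these compounds alone.

Three compounds share one core and differ only in a single group on an aromatic carbon. Compound 1 `Cc1ccc2nc(C(=O)Nc3c(F)cc(-c4cccc(F)c4)cc3F)c(C)c(O)c2c1` carries a methyl there; in a functional assay on A-375 cells (Homo sapiens) for antiproliferative activity, read by MTT assay, with a stated time of 24 h, tested at 0.41 ug/mL (a lower number here means a weaker effect, a higher number a stronger effect of the compound at the concentration tested), compound 1 gives 1.35%. Compound 2 `CCOc1ccc2nc(C(=O)Nc3c(F)cc(-c4cccc(F)c4)cc3F)c(C)c(O)c2c1` carries an ethoxy, and in this assay compound 2 gives 2.05%. Compound 3 `Cc1c(C(=O)Nc2c(F)cc(-c3cccc(F)c3)cc2F)nc2ccc(OC(F)(F)F)cc2c1O` carries a trifluoromethoxy, and in this assay compound 3 gives 1.02%. Compound 3 has the lowest of the three numbers, but every gap is small: a number 0.3 percentage points lower from compound 1 to compound 3 (within the scatter), a number 1 percentage points lower from compound 2 to compound 3 (within the scatter), and a number 0.7 percentage points higher from compound 1 to compound 2 (within the scatter). The three compounds therefore cannot be told apart by this assay.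

Compound 4 `Cc1c(C(=O)Nc2c(F)cc(-c3cccc(F)c3)cc2F)nc2ccc(C(F)(F)F)cc2c1O` is not yet measured. It differs from compound 3 in one place: trifluoromethyl in place of trifluoromethoxy on an aromatic carbon. Going by the values given here, no measured step puts a trifluoromethyl at this position, so the nearest guide is that every change tried there so far, from methyl to ethoxy to trifluoromethoxy, left the read-out unchanged within the scatter. Compound 4 is therefore expected to stay where the others sit, with a step of a number 0.5 percentage points higher from compound 3 to compound 4 (within the scatter) that is expected to lie within the scatter. The estimated value for compound 4 in this assay is 1.5%, with a range from -5% to 8%.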

Compound 4, a percentage reported as inhibition, at one concentration (the size of the read-out at that concentration, not a potency): 16.5%
Beside the measured number, compound 4's estimate is 15 percentage points below it, and the stated range ends below it.
By their numbers in this assay, from the lowest: compounds 3, 1 and 2 (each within the scatter of the next); then compound 4.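

Going by these compounds alone, this position is less indifferent than the earlier compounds suggested: in this assay the change from trifluoromethoxy to trifluoromethyl gives a number 15.5 percentage points higher from compound 3 to compound 4 (beyond the scatter) and moves the read-out beyond the scatter, which no change among methyl, ethoxy and trifluoromethoxy had done. The comparisons with the other two groups point the same way, with a number 14.5 percentage points higher from compound 2 to compound 4 (beyond the scatter) and with a number 15.2 percentage points higher from compound 1 to compound 4 (beyond the scatter) as well, so compound 4 has the strongest effect of the four at the concentration tested, although the steps remain modest and the two groups in the first step differ only by the oxygen that links trifluoromethoxy to the aromatic carbon. Nothing available explains why trifluoromethyl stands apart from the other three groups.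

The compounds shown leave open whether this rise belongs to trifluoromethyl alone or would also appear with a chlorine atom, a nitrile or a pentafluoroethyl chain on the same aromatic carbon. They also leave open how compound 4 behaves at other concentrations, as a read-out at one concentration gives a size and not a potency.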